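This account rests on a few compounds, and the source may have more. Where it says the series, first, only, none or still open, it means among the compounds named here.

Compound 1 `O=C1Nc2ccccc2/C1=N/NC(=S)NCc1ccccc1`: 7630 nM
Compound 2 `COc1ccccc1NC(=S)N/N=C1\C(=O)Nc2ccccc21`: 2690 nM
Compound 3 `COc1cc(NC(=S)N/N=C2\C(=O)Nc3ccccc32)cc(OC)c1OC`: 3490 nM

All three values come from a functional assay on KB-V1 cells (Homo sapiens) for cytotoxicity, read by MTT assay, with a stated time of 72 h; a lower number here means a stronger inhibitor, a higher number a weaker inhibitor. Compound 1 has the highest number of the three, which makes it the weakest inhibitor here, and its gap to each of the other two lies beyond the usual scatter. Compound 2 and compound 3 lie within the scatter of each other.

Compound 4 `O=C1Nc2ccccc2/C1=N/NC(=S)Nc1cccc(Cl)c1` keeps the core of compound 1, with 3-chlorophenyl in place of benzyl on an amide-type nitrogen. Among the measured compounds shown here, no two measured compounds differ in just one place, so this swap has no direct precedent, and the expectation is a loose one. For the measured compounds named here, the only guide is that compound 2 and compound 3 both sit lower than compound 1: compound 1 gives 7630 nM, compound 2 gives 2690 nM and compound 3 gives 3490 nM. A moderate drop in this assay is therefore expected, of about the size of those gaps, though it might not clear the scatter. The estimated change is a 2.5-fold lower number from compound 1 to compound 4 (0.41 log units; beyond the scatter). For compound 4 the estimated value is 3000 nM, with an expected range of 1200 nM to 7000 nM.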

Compound 4, half-maximal inhibitory concentration: 640 nM
For compound 4 the middle estimate is 4.7-fold (0.67 log units) above the measured one; measured number below the stated range.
By their numbers in this assay, from the lowest: compound 4; then compounds 2 and 3 (each within the scatter of the next); then compound 1.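

In this assay, among the compounds shown here, putting 3-chlorophenyl in place of benzyl on the amide-type nitrogen gives a 12-fold lower number from compound 1 to compound 4 (1.08 log units; beyond the scatter), a large step and the first direct reading of a single change. It shows that the number responds strongly to the group at this nitrogen, even though both groups have the same count of heavy atoms and each carries one six-membered aromatic ring. No measurement here explains why the step is so large.

The swap adds a chlorine and also removes the carbon that links the ring to the nitrogen in benzyl, so a plain phenyl group at this nitrogen would be needed to tell those two changes apart. As far as these compounds go, it also remains open whether a bromine or a methyl group in the chlorine's place would give a similar number.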